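A few compounds are considered here, and "the series" means these few. Any claim that something is new, unique, unknown or untested is made for them only; others in the source may bear on it.

In a functional assay on MOLT-4 cells (Homo sapiens) for antiproliferative activity (a lower number here means a stronger inhibitor, a higher number a weaker inhibitor), compound 3 `COc1cc(C(=O)c2sc(-c3ccccc3)cc2N)cc(OC)c1OC` gives 5.3 nM, the lowest number among the measured compounds. Compound 2 `COc1ccc(-c2cc(N)c(C(=O)c3cc(OC)c(OC)c(OC)c3)s2)cc1OC` gives 20 nM. Compound 1 `COc1cc(C(=O)c2sc(-c3ccc(-c4ccccc4)cc3)cc2N)cc(OC)c1OC` reads > 10000 nM, which is a limit of the assay and not a number.

Compound 4 `COc1cc(C(=O)c2sc(-c3ccc(F)cc3)cc2N)cc(OC)c1OC` comes from compound 3 by a single change: fluoro in place of hydrogen on an aromatic carbon. This is fluoro in place of hydrogen on an aromatic carbon, or phenyl to 4-fluorophenyl.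

Among the measured compounds shown here, two measured steps bear on this change, and both end at compound 3. One is large: an at least 1800-fold lower number from compound 1 to compound 3 (3.27 log units; beyond the scatter). The other is modest: a 3.8-fold lower number from compound 2 to compound 3 (0.58 log units; beyond the scatter). In both, the added substitution on compound 3 raises the number, though only two cases support this. Fluoro adds a single heavy atom, so the modest step from compound 2 is the closer guide, and a collapse like that of compound 1 is not expected.

A small rise in this assay is expected, possibly within the scatter. The estimated step is a 1.9-fold higher number from compound 3 to compound 4 (0.28 log units; within the scatter). For compound 4 the expected value is 10 nM, with an estimated range of 3 nM to 35 nM.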

Compound 4, half-maximal inhibitory concentration: 12 nM
Compound 4: the middle estimate sits 1.2-fold (0.08 log units) below what was measured; low and high end bracket the measured number.
By their numbers in this assay, from the lowest: compound 3; then compounds 4 and 2 (each within the scatter of the next). At a limit, above all of these: compound 1.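

In this assay, the position para to a large group on the six-membered aromatic ring takes fluoro at a modest cost, a 2.3-fold higher number from compound 3 to compound 4 (0.35 log units; beyond the scatter), so compound 3, with its unsubstituted phenyl, keeps the lowest number of the series. The comparison with the dimethoxy analogue gives a 1.7-fold lower number from compound 2 to compound 4 (0.22 log units; within the scatter), so the 4-fluorophenyl and 3,4-dimethoxyphenyl groups cannot be told apart here. With an at least 830-fold lower number from compound 1 to compound 4 (2.92 log units; beyond the scatter), this position accepts a single fluoro but not a phenyl, and that step rests on a limit and not a number: the limit of > 10000 nM in this assay, at which 1 of the 4 values shown sits.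

Open, going by these compounds, is how a chloro, a single methoxy or an amine would read at this position, and whether either methoxy group of compound 2 alone would match its value. Also open, on these data alone, is whether this order holds in other cell lines.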